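A few compounds are considered here, and "the series" means these few. Any claim that something is new, unique, unknown or untested is made for them only; others in the source may bear on it.

Working notes on the series, read in an ADME assay on CEM-SS cells (Homo sapiens) for cytotoxicity, read by XTT assay, with a stated time of 6 days; on this read-out higher numbers stand for lower toxicity in this test and lower numbers for higher toxicity in this test. Among the compounds with values here, compound 1 (`CCCC(=O)OCSc1ccccc1C(=O)NCCCC(N)=O`) gives 56.6 uM and compound 2 (`CCCC(=O)OCSc1ccccc1C(=O)N[C@@H]1CCC[C@H]1C(N)=O`) gives 43.7 uM, so compound 2 stands within the scatter of the only other measured compound. Compound 3 (`CCCC(=O)OCSc1ccccc1C(=O)N[C@@H]1CCC[C@@H]1C(N)=O`) relates to compound 2 as follows: the two compounds have the same atoms and bonds and differ only in configuration as drawn: 1 of 2 stereo elements differ; a stereocentre at a saturated ring carbon is drawn R in compound 2 and S in compound 3. Within the data shown here, the one measured step that bears on this is a 1.3-fold lower number from compound 1 to compound 2 (0.11 log units; within the scatter), with 2-carbamoylcyclopentyl in place of 3-carbamoylpropyl on an amide-type nitrogen. Among the measured compounds shown here, that step is a change of group, and no measured pair tests a change of configuration alone, so the evidence is indirect. No step beyond the scatter is expected in this assay, and no direction is favoured. The expected change is a 1.1-fold higher number from compound 2 to compound 3 (0.04 log units; within the scatter). Compound 3 is estimated at 48 uM, with an expected range of 22 uM to 100 uM.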

Compound 3, half-maximal toxic concentration: 90 uM
Estimate against measurement, compound 3: 1.9-fold (0.27 log units) below; low and high end bracket the measured number.
By their numbers in this assay, from the lowest: compounds 2, 1 and 3 (each within the scatter of the next, the first and the last beyond it).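

In this assay the change of configuration alone gives a 2.1-fold higher number from compound 2 to compound 3 (0.31 log units; beyond the scatter) and so shows that the drawn configuration at this saturated ring carbon can shift the number, which the earlier change of group did not show. The other step, a 1.6-fold higher number from compound 1 to compound 3 (0.20 log units; within the scatter), leaves 2-carbamoylcyclopentyl and 3-carbamoylpropyl on the amide-type nitrogen unseparated in this pair, so the ring gives no separate reading here. The modest step can be placed at this single stereocentre on one ground: the fact that compounds 2 and 3 differ only in the configuration as drawn

Whether the second stereo element of the ring has a similar effect stays open, since the compounds shown do not change it alone. Also open, as far as these compounds go, is how a carboxylic acid or a nitrile in place of the carbamoyl group would read in this assay on either configuration.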